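A few compounds are considered here, and "the series" means these few. Any claim that something is new, unique, unknown or untested is made for them only; others in the source may bear on it.

Compound 1 `Oc1ccc2cc(-c3ccc(O)c4ncccc34)oc2c1` was measured in an ADME assay for permeability, using PAMPA, with a stated time of 10 h, tested at 100 ug/mL (on this read-out lower numbers stand for lower permeability and higher numbers for higher permeability), where compound 1 gives 15.8 10^-6 cm/s. Compound 2 `Oc1cc(O)c2cc(-c3ccc(O)c4ncccc34)oc2c1` carries hydroxy in place of hydrogen on an aromatic carbon, and in this assay compound 2 gives 2.6 10^-6 cm/s, a step of a 6.1-fold lower number from compound 1 to compound 2 (0.78 log units; beyond the scatter). Compound 3 `Oc1c(Cl)cc(-c2cc3ccccc3o2)c2cccnc12` rests on a second core; the difference between the two cores is not broken down here. In this assay compound 3 gives 2.6 10^-6 cm/s, the same number as compound 2. Compound 4 `Oc1c(Cl)cc(-c2cc3cccc(O)c3o2)c2cccnc12` carries hydroxy in place of hydrogen on an aromatic carbon; the surroundings of the place differ, since in compound 2 the hydroxy also sits meta to a hydroxy group, so this is the same kind of change rather than the same change. For compound 4 the expected step is a 4.3-fold lower number from compound 3 to compound 4 (0.64 log units; beyond the scatter), resting on the earlier 6.1-fold lower number from compound 1 to compound 2 (0.78 log units; beyond the scatter). The estimate for compound 4 is 0.6 10^-6 cm/s, expected between 0.2 10^-6 cm/s and 2 10^-6 cm/s.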

Compound 4, apparent permeability: 16.4 10^-6 cm/s
The estimate for compound 4 lay 27-fold (1.44 log units) below the measured number; the measured number lies above the stated range.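

In this assay, hydroxy in place of hydrogen on an aromatic carbon gave a 6.3-fold higher number from compound 3 to compound 4 (0.80 log units; beyond the scatter). Set beside the earlier step, the same kind of change moved the number in opposite directions on the two cores: the same change on two cores in this assay, a 6.1-fold lower number (0.78 log units; beyond the scatter) from compound 1 to compound 2 and a 6.3-fold higher number (0.80 log units; beyond the scatter) from compound 3 to compound 4, 38-fold (1.58 log units) apart, beyond the scatter of two such steps. In this series, then, the step seen on one core did not carry over to the other, but with one pair on each core, this does not show what separates the two results, nor does it give a rule for other positions.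

The compounds shown leave open whether a methoxy group or an amine at the place taken by hydroxy in compound 4 would follow the same step. They also leave open whether that step would hold on the core of compound 3 without its chlorine.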